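A few compounds are considered here, and "the series" means these few. Any claim that something is new, unique, unknown or untested is made for them only; others in the source may bear on it.

Measured compounds:
compound 1 `CC(=O)OCCC(=O)O[C@H](CC=C(C)C)C1=CC(=O)c2c(O)ccc(O)c2C1=O` — 17300 nM
compound 2 `COC(C)CO[C@H](CC=C(C)C)C1=CC(=O)c2c(O)ccc(O)c2C1=O` — 53400 nM
compound 3 `COCCO[C@H](CC=C(C)C)C1=CC(=O)c2c(O)ccc(O)c2C1=O` — 62400 nM

These three compounds share one core and differ only in the group on the oxygen on the saturated carbon. In a functional assay on HeLa cells (Homo sapiens) for cytotoxicity, read by MTT assay (on this read-out lower numbers stand for stronger inhibition and higher numbers for weaker inhibition), compound 2 stands second highest of the three numbers: compound 3 lies within the scatter of it, the step being a 1.2-fold higher number from compound 2 to compound 3 (0.07 log units; within the scatter), while compound 1 lies further off, the step being a 3.1-fold higher number from compound 1 to compound 2 (0.49 log units; beyond the scatter). The parallel step a 3.6-fold higher number from compound 1 to compound 3 (0.56 log units; beyond the scatter) is of the same size.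

Compound 4 `CC(C)=CC[C@@H](OCCO)C1=CC(=O)c2c(O)ccc(O)c2C1=O` has not yet been measured. Compared with compound 2 it carries hydroxymethyl in place of 1-methoxyethyl on a saturated chain carbon bound to an oxygen on a saturated carbon. Within the data shown here, no measured pair exchanges a methoxy group for a hydroxyl, so the step bearing most directly on it is the one from compound 2 to compound 3, which removed a methyl from the same chain and stayed within the scatter. Compound 4 is therefore expected to sit close to compound 2, the step of a 1.1-fold lower number from compound 2 to compound 4 (0.05 log units; within the scatter) being the expected one. For compound 4 the estimate is 48000 nM, in the range from 20000 nM to 115000 nM.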

Compound 4, half-maximal inhibitory concentration: 18600 nM
Compound 4: middle estimate off by 2.6-fold (0.41 log units), on the high side, and the stated range ends above it.
By their numbers in this assay, from the lowest: compounds 1 and 4 (each within the scatter of the next); then compounds 2 and 3 (each within the scatter of the next).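

In this assay the methyl on the chain's oxygen proved to count, with 2-hydroxyethyl in place of 2-methoxyethyl giving a 3.4-fold lower number from compound 3 to compound 4 (0.53 log units; beyond the scatter) as its step, whereas the earlier removal of a methyl from the chain, a 1.2-fold higher number from compound 2 to compound 3 (0.07 log units; within the scatter) in size, had changed nothing beyond the scatter. The wider exchange of 2-methoxypropyl for 2-hydroxyethyl gave a 2.9-fold lower number from compound 2 to compound 4 (0.46 log units; beyond the scatter) as its step, and a 1.1-fold higher number from compound 1 to compound 4 (0.03 log units; within the scatter) places 2-hydroxyethyl within the scatter of (2-acetoxyethyl)carbonyl, so a group other than that ester now reaches the same level. No evidence is available to account for these steps. Going by these compounds, whether a longer chain such as 3-hydroxypropyl would keep the level of compound 4 remains open. So does the outcome of replacing the hydroxyl of 2-hydroxyethyl with an amine or a carboxylic acid.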